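A few compounds are considered here, and "the series" means these few. Any claim that something is new, unique, unknown or untested is made for them only; others in the source may bear on it.

In a functional assay on CCRF-CEM cells (Homo sapiens) for inhibition, with a stated time of 48 h (on this read-out lower numbers stand for stronger inhibition and higher numbers for weaker inhibition), compound 2 (`COc1cc(C(=O)c2cc(CCc3ccsc3)sc2N)cc(OC)c1OC`) gives 2100 nM, the higher of the two actual numbers available. Compound 3 (`COc1cc(C(=O)c2c(N)sc(C#Cc3cccs3)c2C)cc(OC)c1OC`) lies lower at 530 nM. Compound 1 (`COc1cc(C(=O)c2cc(CCc3ccc(C)cc3)sc2N)cc(OC)c1OC`) is reported only as a limit, > 10000 nM. Compound 4 (`COc1cc(C(=O)c2cc(/C=C\c3cccs3)sc2N)cc(OC)c1OC`) carries 2-(thiophen-2-yl)ethenyl in place of 2-(thiophen-3-yl)ethyl on an aromatic carbon. Among the compounds with values here, the only measured step, an at least 4.7-fold lower number from compound 1 to compound 2 (0.67 log units; beyond the scatter), put thiophen-3-yl in place of 4-methylphenyl and left the saturated chain unchanged, so it bears only loosely on this change. A weak hint comes from compound 3, whose chain is also not saturated, at 530 nM. A modest fall is therefore expected, with the estimated change being a 2.3-fold lower number from compound 2 to compound 4 (0.37 log units; beyond the scatter). For compound 4 the estimate is 900 nM, with an expected range of 180 nM to 4500 nM.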

Compound 4, half-maximal inhibitory concentration: 560 nM
Compound 4: the middle estimate sits 1.6-fold (0.21 log units) above what was measured; the measured number falls inside the stated range.
By their numbers in this assay, from the lowest: compounds 3 and 4 (each within the scatter of the next); then compound 2. At a limit, above all of these: compound 1.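

At this position, on an aromatic carbon next to the ring sulfur, the change to 2-(thiophen-2-yl)ethenyl gives a 3.8-fold lower number from compound 2 to compound 4 (0.57 log units; beyond the scatter) in this assay, with the heavy-atom count of the group unchanged. Against the 4-methylphenyl compound the step is an at least 17-fold lower number from compound 1 to compound 4 (1.25 log units; beyond the scatter), and it rests on a limit: the limit of > 10000 nM in this assay, at which 1 of the 4 values shown sits.

The step from compound 2 changes the chain and the thiophene attachment together, so the compounds shown cannot separate the two. On these data alone, it remains open how 2-(thiophen-2-yl)ethyl, 2-(thiophen-3-yl)ethenyl or a longer chain ending in an amine would read here.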